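This account rests on a few compounds, and the source may have more. Where it says the series, first, only, none or still open, it means among the compounds named here.

Measured compounds:
- compound 1, `C/C=C/COc1cc(/C=C\c2cc(OC)c(OC)c(OC)c2)ccc1OC`, 161000 nM
- compound 2, `COc1ccccc1/C=C/CCCOc1cc(/C=C\c2cc(OC)c(OC)c(OC)c2)ccc1OC`, 86000 nM
- compound 3, `COc1cccc(/C=C/CCCOc2cc(/C=C\c3cc(OC)c(OC)c(OC)c3)ccc2OC)c1`, 25000 nM

All three share one core and differ only in the chain on the oxygen of the aromatic ring. In a functional assay on HT-29 cells (Homo sapiens) for inhibition, read by MTT assay, with a stated time of 3 days (a higher number here means a weaker inhibitor, a lower number a stronger inhibitor), compound 2 gives the second highest of the three numbers; compound 1 sits close by (a 1.9-fold lower number from compound 1 to compound 2 (0.27 log units; within the scatter)), while compound 3 lies further off (a 3.4-fold lower number from compound 2 to compound 3 (0.54 log units; beyond the scatter)).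

The unmeasured compound 4, `COc1ccc(/C=C\c2cc(OC)c(OC)c(OC)c2)cc1OCCC/C=C/c1ccc(Cl)cc1`, is compound 2 with one change: 4-chlorophenyl in place of 2-methoxyphenyl on a double-bonded chain carbon bound to a double-bonded chain carbon. Among the measured compounds shown here, only one measured step alters the aryl group at this place, a 3.4-fold lower number from compound 2 to compound 3 (0.54 log units; beyond the scatter), and it moved the methoxy group rather than swapping it for chlorine. For the measured compounds named here, no step shows a chlorine here. A modest lowering of the number, as seen for compound 3, is therefore the most that can be expected, and a step within the scatter is just as plausible.

Compound 4 is expected to reach 45000 nM, between 12000 nM and 150000 nM, which would mean a 1.9-fold lower number from compound 2 to compound 4 (0.28 log units; within the scatter).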

Compound 4, half-maximal inhibitory concentration: 18000 nM
The estimate for compound 4 lay 2.5-fold (0.40 log units) above the measured number; low and high end bracket the measured number.
By their numbers in this assay, from the lowest: compounds 4 and 3 (each within the scatter of the next); then compounds 2 and 1 (each within the scatter of the next).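

Putting 4-chlorophenyl in place of 2-methoxyphenyl lowers the number in this assay by more than the scatter (a 4.8-fold lower number from compound 2 to compound 4 (0.68 log units; beyond the scatter)), so this aryl group need not carry a methoxy group to do well here. Against the 3-methoxyphenyl group, the change stays within the scatter (a 1.4-fold lower number from compound 3 to compound 4 (0.14 log units; within the scatter)), so 4-chlorophenyl and 3-methoxyphenyl cannot be told apart at this place. Measured against the short prop-1-en-1-yl chain of compound 1, the 4-(4-chlorophenyl)but-3-en-1-yl chain gives the largest step in the set (an 8.9-fold lower number from compound 1 to compound 4 (0.95 log units; beyond the scatter)).

Nothing available explains why these numbers shift. The compounds shown leave open how an amine or a carboxylic acid in place of the chlorine, or a longer chain, would behave at this place.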